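This account rests on a few compounds, and the source may have more. Where it says the series, first, only, none or still open, it means among the compounds named here.

Measured compounds:
compound 1 `CC(C)C[C@H](N)c1cc(C(F)(F)F)ccc1N1CCN(C(=O)COc2ccc3ccccc3c2)CC1` — 2000 nM
compound 2 `CC(C)C[C@H](N)c1cc(C(F)(F)F)ccc1N1CCN(C(=O)C(C)Cc2ccc(Cl)cc2)CC1` — 47 nM
compound 3 `CC(C)C[C@H](N)c1cc(C(F)(F)F)ccc1N1CCN(C(=O)[C@H](C)Cc2ccc(Cl)cc2)CC1` — 31 nM

Notes on the series. In an assay on HEK293 cells for displacement of a labelled ligand from Melanocortin receptor 4 (Homo sapiens) (on this read-out higher numbers stand for weaker inhibition and lower numbers for stronger inhibition), compound 3 gives the lowest of the three numbers; compound 2 sits within the scatter of it, as a 1.5-fold lower number from compound 2 to compound 3 (0.18 log units; within the scatter) shows, and compound 1 is far above it. Within the data shown here, the only structural distinction between compound 2 and compound 3 is the fact that one of compounds 2 and 3 is drawn with a defined configuration and the other without, at the place where they differ, so the gap between them carries no structural message.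

Compound 4 `CC(C)C[C@H](N)c1cc(C(F)(F)F)ccc1N1CCN(C(=O)CC(C)C(=O)c2ccc(Cl)cc2)CC1` differs from compound 3 by 2-((4-chlorophenyl)carbonyl)propyl in place of 1-(4-chlorobenzyl)ethyl on a carbonyl carbon. Among the measured compounds shown here, no measured pair changes this part of the molecule in the same way. The closest information is that the group on this carbonyl carbon matters a great deal: a 43-fold lower number from compound 1 to compound 2 (1.63 log units; beyond the scatter) and a 65-fold lower number from compound 1 to compound 3 (1.81 log units; beyond the scatter) were both large when the chain and aryl group were changed. Inserting a second carbonyl into the chain and lengthening it is therefore expected to move this assay noticeably, and a rise in the number is judged more likely than a fall.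

Compound 4 is expected to give 150 nM in this assay, within 40 nM to 600 nM, a step of a 4.8-fold higher number from compound 3 to compound 4 (0.68 log units; beyond the scatter).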

Compound 4, inhibition constant: 1100 nM
The estimate for compound 4 lay 7.3-fold (0.87 log units) below the measured number, and the stated range ends below it.
By their numbers in this assay, from the lowest: compounds 3 and 2 (each within the scatter of the next); then compounds 4 and 1 (each within the scatter of the next).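

In this assay, a group that keeps the 4-chlorophenyl ring can still lose the low numbers of this series: a 35-fold higher number from compound 3 to compound 4 (1.55 log units; beyond the scatter) and a 23-fold higher number from compound 2 to compound 4 (1.37 log units; beyond the scatter) are both large, so the ring alone does not hold the number down. With a 1.8-fold lower number from compound 1 to compound 4 (0.26 log units; within the scatter) inside the scatter, the 2-((4-chlorophenyl)carbonyl)propyl group reads the same as the ((naphthalen-2-yl)oxy)methyl group, although the two differ in their aryl rings. Nothing measured here bears on why this change has so large an effect.

As far as these compounds go, compound 4 adds the carbonyl and alters the chain in one step, so which of the two carries the loss remains open. Also open, from the compounds shown here alone, are whether a hydroxyl group or an amine in place of that carbonyl would restore the low number, and whether the stereocentre drawn without a configuration in compound 4 matters.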